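The source may hold more compounds than are shown below. What is called first, only, known or untested is meant among the compounds shown, and "the series" means these compounds.

Compound 3 `COc1cc(C(N)=O)cc2nc(NC(=O)c3cccnn3)n(CCCNC(=O)OCc3ccccc3)c12` stands at the limit of > 100000 nM in this assay, at which 3 of the 3 values shown sit, of an assay for activation of interferon regulatory factor 3 (Homo sapiens), read by a luciferase reporter, with a stated time of 20 h; a lower number here means that less compound is needed, a higher number that more compound is needed for the effect: in this assay compound 3 gives no number, only the limit > 100000 nM. Compound 1 `CCCn1c(NC(=O)c2ccc3ccccc3n2)nc2cc(C(N)=O)cc(OC)c21` likewise gives only the limit > 100000 nM. Compound 2 `CCCn1c(NC(=O)c2cccnn2)nc2cc(C(N)=O)cc(OC)c21` also gives only the limit > 100000 nM. The step from compound 1 to compound 2, a step that the two limits leave unreadable from compound 1 to compound 2, and the step from compound 2 to compound 3, a step that the two limits leave unreadable from compound 2 to compound 3, are thus both unreadable in size and direction. Compound 4 `COc1cc(C(N)=O)cc2nc(NC(=O)C3CCCN3C)n(CCCNC(=O)OCc3ccccc3)c12` differs from compound 3 by 1-methylpyrrolidin-2-yl in place of pyridazin-3-yl on a carbonyl carbon. For the measured compounds named here, no measured step gives a readable size for a change of this kind, so no step beyond the scatter can be expected in either direction. Compound 4 is therefore estimated at 150000 nM, with a range from 30000 nM to 500000 nM. This amounts to an expected step that the limit leaves unreadable from compound 3 to compound 4.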

Compound 4, half-maximal effective concentration: > 100000 nM
Compound 4: no number, only a limit; the forecaster's own chance of this, stated with the estimate: 80%; the middle value does not contradict the limit.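

Compound 3 and compound 4 both give only a limit, not a number, so no step between them can be read: the limit of > 100000 nM in this assay, at which 4 of the 4 values shown sit.

The compounds shown leave open whether any change to these structures would give a real number in this assay.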